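The compounds below may be only part of what the source reports. "The series", "measured", "known", "first", "only" and "open" are said of these compounds alone.

Compound 1 `CCCC(=O)NCCCc1ccccc1OC` gives 442 nM in an assay for binding affinity to melatonin receptor (Gallus gallus); on this read-out lower numbers stand for stronger inhibition and higher numbers for weaker inhibition. Compound 2 `CCCCC(=O)NCCCc1ccccc1OC` reaches only a limit in this assay, > 100000 nM, and no number. Compound 3 `COc1ccc(CCCCNC(C)=O)cc1` gives 7300 nM in this assay.

The step from compound 1 to compound 2 is the change (methyl in place of hydrogen on a saturated chain carbon, three bonds along the chain from a carbonyl carbon), and it brought an at least 220-fold higher number from compound 1 to compound 2 (2.35 log units; beyond the scatter); its end point is set by the limit of > 100000 nM in this assay, at which 1 of the 3 values shown sits, rather than by a measured number, so the true size of the loss is not known. Compound 3 stands apart from compound 1 in more than one place, and the difference between the two cores is not broken down here. Their values show compound 3 with the weaker binding of the two.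

Compound 4 `CCC(=O)NCCCCc1ccc(OC)cc1` has not yet been measured. It differs from compound 3 by methyl in place of hydrogen on a saturated chain carbon bound to a carbonyl carbon. Among the measured compounds shown here, this is the same kind of change as the one from compound 1 to compound 2, but not the same: there the methyl entered on a saturated chain carbon three bonds along the chain from a carbonyl carbon, here it enters on a saturated chain carbon bound to a carbonyl carbon. For the measured compounds named here, the only measured instance of the kind points to a loss, yet the place differs and the two cores differ, so the step from compound 3 to compound 4 is expected to be small, around a 1.8-fold lower number from compound 3 to compound 4 (0.26 log units; within the scatter). Compound 4 is therefore estimated at 4000 nM in this assay, within a range from 800 nM to 25000 nM.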

Compound 4, inhibition constant: 1400 nM
Compound 4: the middle estimate sits 2.9-fold (0.46 log units) above what was measured, within the range that was stated.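

In this assay, turning the acetamido group of compound 3 into the propanoylamino group of compound 4 brought a 5.2-fold lower number from compound 3 to compound 4 (0.72 log units; beyond the scatter), a modest gain in binding, whereas the same kind of change cost binding on the other core, so in these two cases it did not carry over with the same outcome: the same change on two cores in this assay, an at least 220-fold higher number (2.35 log units; beyond the scatter) from compound 1 to compound 2 and a 5.2-fold lower number (0.72 log units; beyond the scatter) from compound 3 to compound 4, at least 1100-fold (3.07 log units) apart, beyond the scatter of two such steps. This does not show what separates the two results, since the steps differ both in the core and in the place of the methyl, on a saturated chain carbon bound to a carbonyl carbon in one and three bonds along the chain from a carbonyl carbon in the other, and a single pair on each core cannot pull these apart. The size of the earlier loss also stays uncertain, as compound 2 gives a limit and not a number: the limit of > 100000 nM in this assay, at which 1 of the 4 values shown sits.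

The compounds shown leave open whether the methyl would have the same outcome at the same place on both cores, and whether a butanoylamino group on the core of compound 3 would bind better or worse than the propanoylamino group of compound 4. They also leave open how a branched or ring-bearing acyl group, such as isobutyryl or cyclopropanecarbonyl, would fare on either core.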